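Second methoxy on the benzamide aryl: a repeated change

The compounds below may be only part of what the source reports. "The series", "measured", "known", "first", "only" and "open" are said of these compounds alone.

Compound 1 `COc1ccc(C(=O)Nc2ccc(N(C)S(C)(=O)=O)c(OCc3cc(C(F)(F)F)ccc3C)c2)cc1` gives 2030 nM in a functional assay on SK-BR-3 cells (Homo sapiens) for antiproliferative activity, read by MTT assay, with a stated time of 48 h; on this read-out higher numbers stand for weaker inhibition and lower numbers for stronger inhibition. Compound 2 `COc1ccc(C(=O)Nc2ccc(N(C)S(C)(=O)=O)c(OCc3cc(C(F)(F)F)ccc3C)c2)cc1OC` differs by methoxy in place of hydrogen on an aromatic carbon and gives 16900 nM; the step is an 8.3-fold higher number from compound 1 to compound 2 (0.92 log units; beyond the scatter). Compound 3 `COc1ccc(C(=O)Nc2ccc(N(C)S(=O)(=O)C(F)(F)F)c(OCc3cc(OC)ccc3OC)c2)cc1` carries a different core, and the difference between the cores of compound 3 and compound 1 is not broken down here; in this assay compound 3 gives 110 nM, the lowest number of the three measured.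

Compound 4 `COc1ccc(OC)c(COc2cc(NC(=O)c3ccc(OC)c(OC)c3)ccc2N(C)S(=O)(=O)C(F)(F)F)c1` is not yet measured. It differs from compound 3 by methoxy in place of hydrogen on an aromatic carbon, with the same surroundings as the change from compound 1 to compound 2, so it is the same change on a different core. For the measured compounds named here, the only measured instance weakened inhibition, and compound 3 starts from a stronger position than compound 1 did, so some of that weakening is expected to carry over, though the core differs and the transfer is uncertain. Compound 4 is therefore expected to give about 600 nM, in the range 150 nM to 2500 nM. This implies an expected step of a 5.5-fold higher number from compound 3 to compound 4 (0.74 log units; beyond the scatter), resting on the change from compound 1 to compound 2.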

Compound 4, half-maximal inhibitory concentration: 550 nM
For compound 4 the middle estimate is 1.1-fold (0.04 log units) above the measured one, and the stated range covers the measured number.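

Going from 4-methoxyphenyl to 3,4-dimethoxyphenyl in this assay gives a 5.0-fold higher number from compound 3 to compound 4 (0.70 log units; beyond the scatter), so the weaker inhibition seen on the first core appears again on a second one. The two steps point the same way and do not differ in size: the same change on two cores in this assay, an 8.3-fold higher number (0.92 log units; beyond the scatter) from compound 1 to compound 2 and a 5.0-fold higher number (0.70 log units; beyond the scatter) from compound 3 to compound 4, 1.7-fold (0.22 log units) apart, within the scatter of two such steps

Within this series, the change therefore carries across these two cores as a similar loss, and the step from one core can serve as a working estimate for the other. For the compounds shown here, this rests on only two matched pairs in a single cell assay; it does not show that the step would hold on any further core, and it gives no reason for the loss.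

Going by these compounds, it remains open whether the loss is specific to methoxy or would also follow from another group ortho to the existing methoxy, such as a hydroxyl, an ethoxy, a fluorine or an amine. On these data alone, the separate contributions of the parts that differ between the two cores also remain open.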